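The compounds below may be only part of what the source reports. "The series", "measured", "known", "first", "only" and "open" are said of these compounds alone.

Going by the values given here, compound 1 `ClCc1ccc(Cn2cnc3c(Cl)ncnc32)cc1` is one of two compounds measured in a functional assay on OVCAR-8 cells (Homo sapiens) for cytotoxicity, read by sulforhodamine B assay, with a stated time of 48 h (on this read-out higher numbers stand for weaker inhibition of growth and lower numbers for stronger inhibition of growth), and in it compound 1 gives 3020 nM. This is the higher of the two numbers recorded, but only by a margin that stays within the scatter of the measurement: compound 2 `ClCc1ccccc1Cn1cnc2ncnc(Cl)c21`, which carries the same substituted benzyl group attached through the other ring position, gives 2750 nM in this assay, so the two values show no difference that can be read as a change in potency.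

Compound 3 `ClCc1ccc(Cn2cnc3c(Cl)nc(Cl)nc32)cc1` has not yet been measured. It differs from compound 1 in a single place: chloro in place of hydrogen on an aromatic carbon, namely on the aromatic carbon that sits between two ring nitrogen atoms of the fused core, meta to the existing chloro group. Among the compounds with values here, no measured pair shows the effect of this chloro for hydrogen exchange, so there is no step from which its size can be read. Within the data shown here, with two near-identical values as the only guide, the step from compound 1 to compound 3 is expected to be small, a 1.2-fold lower number from compound 1 to compound 3 (0.08 log units; within the scatter), and not clearly beyond the scatter in either direction. For compound 3 the estimated value in this assay is 2500 nM, with a plausible range from 800 nM to 8000 nM.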

Compound 3, concentration for 50% growth inhibition: 20000 nM
Estimate against measurement, compound 3: 8.0-fold (0.90 log units) below, outside the stated range (above it).
By their numbers in this assay, from the lowest: compounds 2 and 1 (each within the scatter of the next); then compound 3.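

In this assay, chloro in place of hydrogen on the aromatic carbon between two ring nitrogen atoms gives a 6.6-fold higher number from compound 1 to compound 3 (0.82 log units; beyond the scatter), which means weaker inhibition of growth. Going by these compounds alone, this is the first sign that the position matters in these cells: compounds 1 and 2 both carry hydrogen there, so their values said nothing about a change at this carbon, whereas this single added chlorine atom moves the read-out beyond the scatter. The data give no reason for this loss of growth inhibition, and no separate measurement bears on it.

The compounds shown leave open whether the loss belongs to chloro alone or would also follow from other groups on this carbon, such as an amine, a methoxy group or a methyl group. They also leave open whether the same exchange would have a step of similar size in compound 2, since a single pair cannot show how far the effect carries over to a different attachment of the substituted benzyl group.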